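The source may hold more compounds than are shown below. What is called first, only, known or untested is meant among the compounds shown, and "the series" means these compounds.

Of the compounds shown here, three sharing one core have been measured in an assay on CHO-K1 cells for antagonist activity at transient receptor potential cation channel subfamily V member 1 (Homo sapiens), read by FLIPR; a higher number here means a weaker inhibitor, a lower number a stronger inhibitor. Compound 1 `CC(C(=O)NCc1ccc(C(F)(F)F)nc1SCCOc1ccccc1)c1ccc(NS(C)(=O)=O)c(F)c1` gives 2.3 nM. Compound 2 `CC(C(=O)NCc1ccc(C(F)(F)F)nc1SCCC(=O)N1CCCC1)c1ccc(NS(C)(=O)=O)c(F)c1` gives 85 nM, and compound 3 `CC(C(=O)NCc1ccc(C(F)(F)F)nc1SCc1ccc(Cl)cc1)c1ccc(NS(C)(=O)=O)c(F)c1` gives 8.7 nM. Among these three, compound 3 stands second highest: it gives a higher number than compound 1, by a 3.8-fold higher number from compound 1 to compound 3 (0.58 log units; beyond the scatter), and a lower number than compound 2, by a 9.8-fold lower number from compound 2 to compound 3 (0.99 log units; beyond the scatter).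

Compound 4 `CC(C(=O)NCc1ccc(C(F)(F)F)nc1SCCc1ccccc1)c1ccc(NS(C)(=O)=O)c(F)c1` differs from compound 3 in one place: benzyl in place of 4-chlorophenyl on a saturated chain carbon bound to a sulfur. The sulfur-bound carbon thus carries benzyl instead of 4-chlorophenyl, so the chain between the sulfur and the aromatic ring becomes one carbon longer and the chlorine is gone. Going by the values given here, two measured steps bear on this change, both ending at compound 3: the modest one of a 3.8-fold higher number from compound 1 to compound 3 (0.58 log units; beyond the scatter), where a chain of comparable length carrying an aromatic ring gave the strongest number, and the larger one of a 9.8-fold lower number from compound 2 to compound 3 (0.99 log units; beyond the scatter), where the aromatic ring outperformed a chain ending in a carbonyl-bearing ring. Since compound 4 keeps an aromatic ring at a chain length closer to that of compound 1, the expected step is a modest move toward a lower number, of a 1.7-fold lower number from compound 3 to compound 4 (0.24 log units; within the scatter). Compound 4 is therefore estimated to give 5 nM, with a range from 1.5 nM to 20 nM.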

Compound 4, inhibition constant: 1.9 nM
For compound 4 the middle estimate is 2.6-fold (0.42 log units) above the measured one, and the stated range covers the measured number.
By their numbers in this assay, from the lowest: compounds 4 and 1 (each within the scatter of the next); then compound 3; then compound 2.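

In this assay, phenyl in place of phenoxy on a saturated chain carbon, two bonds along the chain from a sulfur, gives a 1.2-fold lower number from compound 1 to compound 4 (0.08 log units; within the scatter), so the oxygen of phenoxy can be removed with no change that this assay can separate from the scatter. At the same place, phenyl in place of (pyrrolidin-1-yl)carbonyl gives a 45-fold lower number from compound 2 to compound 4 (1.65 log units; beyond the scatter), which shows that the group at the end of this chain matters far more here than that oxygen does. The change from 4-chlorobenzyl to phenethyl gives a 4.6-fold lower number from compound 3 to compound 4 (0.66 log units; beyond the scatter), a step beyond the scatter, although it alters the chain length and removes the chlorine at the same time.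

These compounds cannot show which of those two alterations produces that step, a question that benzylsulfanyl without the chlorine or 4-chlorophenethylsulfanyl would separate, and they do not show what a still longer chain, such as 3-phenylpropyl, or an amine at the chain end would give. Nothing available explains why any of these steps has the size it has.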